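Pyridin-2-yl for hydroxy: from compound 2 to compound 4

The source may report more compounds than this note shows. Statements on the series, on what has been measured and on what is new or still open speak of the compounds shown alone.

In a functional assay on Bel-7402 cells (Homo sapiens) for inhibition, read by MTT assay, with a stated time of 24 h, tested at 100 ug/mL (a lower number here means less inhibition of growth, a higher number more inhibition of growth at the concentration tested), compound 1 `O=C(O)CCCCC(CCSC(=O)c1ccccc1)SC(=O)c1ccccc1` gives 81%. Compound 2 `O=C(CCCCC(S)CCS)NO` gives 47.5%, the lowest number of the three, and compound 3 `O=C(CCCCC(S)CCS)Nc1ccc(OC(F)(F)F)cc1` gives 49.7%. Compound 2 and compound 3 agree within the scatter, whereas compound 1 lies beyond the scatter from compound 2. Compound 4 `O=C(CCCCC(S)CCS)Nc1ccccn1` departs from compound 2 by one change: pyridin-2-yl in place of hydroxy on an amide-type nitrogen. Going by the values given here, no measured pair differs in one place only. Compound 3, also changed on that nitrogen, gives 49.7%, so no shift beyond the scatter is expected in this assay. The expected step of a number 2.5 percentage points higher from compound 2 to compound 4 (within the scatter) stays within the scatter. For compound 4 the estimate is 50%, with an expected range of 35% to 68%.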

Compound 4, percent growth inhibition at one concentration: 3.62%
Compound 4: the middle estimate sits 46.4 percentage points above what was measured; the measured number lies below the stated range.
By their numbers in this assay, from the lowest: compound 4; then compounds 2 and 3 (each within the scatter of the next); then compound 1.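

In this assay pyridin-2-yl in place of hydroxy on the amide-type nitrogen gives a number 43.9 percentage points lower from compound 2 to compound 4 (beyond the scatter), so this position is not indifferent to what it carries. An aromatic ring there does not alone set the number: compound 3 gives 49.7%, while compound 4 gives 3.62%. Nothing measured on these compounds accounts for the step.

From the compounds shown here alone, whether the ring nitrogen of pyridin-2-yl or the ring as a whole matters stays open. Plain phenyl or pyridin-4-yl on the same nitrogen would separate the two.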